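From Chloro to Trifluoromethyl on the Aromatic Ring

The source may hold more compounds than are shown below. What is called first, only, known or untested is meant among the compounds shown, and "the series" means these compounds.

In a functional assay on HeLa cells (Homo sapiens) for cytotoxicity, read by MTT assay, with a stated time of 48 h (on this read-out higher numbers stand for weaker inhibition and lower numbers for stronger inhibition), compound 1 `C=C(c1ccc(C)cc1)c1cc(OC)c(OC)c(OC)c1-c1ccccc1` gives 28000 nM and compound 2 `C=C(c1ccc(Cl)cc1)c1cc(OC)c(OC)c(OC)c1-c1ccccc1` gives 34000 nM as its reading, so compound 2 stands level with compound 1 within the scatter. Among the measured compounds shown here, the only measured step, a 1.2-fold higher number from compound 1 to compound 2 (0.08 log units; within the scatter) for chloro in place of methyl on an aromatic carbon, bears on compound 3 `C=C(c1ccc(C(F)(F)F)cc1)c1cc(OC)c(OC)c(OC)c1-c1ccccc1` which has trifluoromethyl in place of chloro on an aromatic carbon as its one difference from compound 2. For the measured compounds named here, with only that small step as a guide, no step beyond the scatter is expected in this assay for this change. Compound 3 is estimated at 30000 nM with an expected range from 13000 nM to 70000 nM in this read-out. The estimate means an expected 1.1-fold lower number from compound 2 to compound 3 (0.05 log units; within the scatter) in all.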

Compound 3, half-maximal inhibitory concentration: 32000 nM
The estimate for compound 3 lay 1.1-fold (0.03 log units) below the measured number, and the stated range covers the measured number.
By their numbers in this assay, from the lowest: compounds 1, 3 and 2 (each within the scatter of the next).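

In this assay, trifluoromethyl in place of chloro gives a 1.1-fold lower number from compound 2 to compound 3 (0.03 log units; within the scatter) and trifluoromethyl in place of methyl gives a 1.1-fold higher number from compound 1 to compound 3 (0.06 log units; within the scatter) at this position. Methyl, chloro and trifluoromethyl therefore all read level here, and going from 1 heavy atom to 4 heavy atoms moves the number no further than the scatter. No evidence is available to explain this level reading. From the compounds shown here alone, whether an amine, a carboxylic acid or a hydroxyl group at this position would move the number beyond the scatter stays open, as does the effect of changes elsewhere on the shared core.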